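Isobutoxycarbonyl compounds: hydrogen in place of fluoro

A few compounds are considered here, and "the series" means these few. Any claim that something is new, unique, unknown or untested is made for them only; others in the source may bear on it.

Measured in a functional assay on the whole organism for inhibition, with Scenedesmus acutus as the target; on this read-out higher numbers stand for weaker inhibition and lower numbers for stronger inhibition:
- compound 1 `COC(=O)c1cc(N2C(=O)C3=C(CCCC3)C2=O)ccc1Cl`: 1780 nM
- compound 2 `CC(C)OC(=O)c1cc(N2C(=O)C3=C(CCCC3)C2=O)ccc1Cl`: 1230 nM
- compound 3 `CC(C)COC(=O)c1cc(N2C(=O)C3=C(CCCC3)C2=O)c(F)cc1Cl`: 100 nM

Compound 3 holds the lowest number of the three, and its gaps to compound 1 and compound 2 both lie beyond the scatter. Compound 4 `CC(C)COC(=O)c1cc(N2C(=O)C3=C(CCCC3)C2=O)ccc1Cl` is still unmeasured. Its difference from compound 3 is hydrogen in place of fluoro on an aromatic carbon, in short hydrogen in place of fluoro on an aromatic carbon.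

Going by the values given here, no measured step isolates this change. Among the compounds with values here, the only single-place step, a 1.4-fold lower number from compound 1 to compound 2 (0.16 log units; within the scatter), exchanges methyl for isopropyl and stays within the scatter. Compound 3 differs from compound 2 in two places, the ester group and the fluoro, so the gap between their values cannot be divided with certainty. Compound 4 lacks the fluoro, as do compound 1 at 1780 nM and compound 2 at 1230 nM, so a value near theirs is expected, assuming the isobutoxycarbonyl group follows the small step seen there. In this assay a large move to a higher number, beyond the scatter, is therefore expected. The expected size is a 10-fold higher number from compound 3 to compound 4 (1.00 log units; beyond the scatter). For compound 4 the estimate is 1000 nM, with an expected range of 400 nM to 2500 nM.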

Compound 4, half-maximal inhibitory concentration: 977 nM
Compound 4: the middle estimate sits 1.0-fold (0.01 log units) above what was measured, within the range that was stated.
By their numbers in this assay, from the lowest: compound 3; then compounds 4, 2 and 1 (each within the scatter of the next).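

In this assay, going by these compounds alone, the step of a 9.8-fold higher number from compound 3 to compound 4 (0.99 log units; beyond the scatter) is the first single-place reading of the fluoro on this aromatic carbon, ortho to a large group and para to an isobutoxycarbonyl group, and it lies beyond the scatter. Among the compounds carrying hydrogen at this position, the ester group gives no such step: a 1.3-fold lower number from compound 2 to compound 4 (0.10 log units; within the scatter) and a 1.8-fold lower number from compound 1 to compound 4 (0.26 log units; within the scatter) both stay within the scatter, so isobutyl joins methyl and isopropyl as a variation with no readable effect in this set. Nothing available here bears on why the exchange of fluoro for hydrogen carries this size of step.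

The compounds shown leave open whether the fluoro step has the same size with the methyl or isopropyl ester, since it is read only on the isobutoxycarbonyl compounds. They also leave open how a methoxy group or a nitrile would read at this aromatic carbon, and whether a carboxylic acid or a longer chain on the ester oxygen would stay within the scatter.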